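Chloro-to-bromo swap on the anilide of a triazolylthio series

The source may report more compounds than this note shows. Statements on the series, on what has been measured and on what is new or still open speak of the compounds shown alone.

Measured compounds:
compound 1 `CC(C)COc1ccc(NC(=O)CCCCCCCSc2nnc(Cc3nn(C)c(=O)c4ccccc34)n2C)cc1` — 25000 nM
compound 2 `Cn1c(Cc2nn(C)c(=O)c3ccccc23)nnc1SCCCCCCCC(=O)Nc1ccc(Cl)cc1Cl` — 19100 nM
compound 3 `Cn1c(Cc2nn(C)c(=O)c3ccccc23)nnc1SCC(=O)Nc1ccc(Cl)cc1Cl` — 48400 nM

All three share one core and differ in the anilide and in the chain linking it to the triazolylthio group. In an assay on isolated protein for binding affinity to interleukin-15 (Homo sapiens), read by surface plasmon resonance (a lower number here means tighter binding, a higher number weaker binding), compound 2 gives 19100 nM, the lowest number of the three. Compound 1 sits a short way above it, and the step of a 1.3-fold lower number from compound 1 to compound 2 (0.12 log units; within the scatter) is within the scatter, so the two cannot be ranked. For the measured compounds named here, compound 3 gives 48400 nM, and its gap to compound 2 lies beyond the scatter; compound 3 carries the short two-carbon linker where compound 2 carries the long one, and no single-change step covers that pair.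

Compound 4 `Cn1c(Cc2nn(C)c(=O)c3ccccc23)nnc1SCCCCCCCC(=O)Nc1ccc(Br)cc1Br` is not yet measured. It differs from compound 2 by one change: 2,4-dibromophenyl in place of 2,4-dichlorophenyl on an amide-type nitrogen. Going by the values given here, no measured step swaps one halogen for another on this ring, so there is no direct precedent. Among the compounds with values here, the one step that touches the anilide, a 1.3-fold lower number from compound 1 to compound 2 (0.12 log units; within the scatter), exchanged the whole aryl group for a different one and still stayed within the scatter, which suggests the anilide tolerates variation. A bromine-for-chlorine swap is a smaller change than that, so no step beyond the scatter is expected in this assay, in either direction.

For compound 4 the estimate is 17000 nM, with a range of 8000 nM to 40000 nM, which corresponds to an expected step of a 1.1-fold lower number from compound 2 to compound 4 (0.05 log units; within the scatter).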

Compound 4, dissociation constant: 11600 nM
Estimate against measurement, compound 4: 1.5-fold (0.17 log units) above; low and high end bracket the measured number.
By their numbers in this assay, from the lowest: compounds 4, 2, 1 and 3 (each within the scatter of the next, the first and the last beyond it).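

In this assay, for the compounds shown here, putting 2,4-dibromophenyl in place of 2,4-dichlorophenyl on the amide-type nitrogen gives a 1.6-fold lower number from compound 2 to compound 4 (0.22 log units; within the scatter) as the first halogen exchange on this ring, so the two halogens cannot be told apart at this position. The dibromo anilide does separate from the 4-(isobutoxy)phenyl anilide, with a 2.2-fold lower number from compound 1 to compound 4 (0.33 log units; beyond the scatter) as a modest step that clears the scatter, whereas a 1.3-fold lower number from compound 1 to compound 2 (0.12 log units; within the scatter) on the dichloro side does not, so the aryl group here can shift the number slightly, though only for this one pair. No measurement among the compounds shown bears on why the numbers fall as they do.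

Going by these compounds, it remains open whether the 2,4-dibromophenyl anilide keeps its number on the short two-carbon linker of compound 3, since halogen exchange has been read only on the long chain. Also open, on these data alone, is how far this position extends beyond halogens and the isobutoxy ether, for instance with a trifluoromethyl group, a carboxylic acid or an amine on the ring, or with a still longer chain.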